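The source may hold more compounds than are shown below. What is called first, only, known or untested is meant among the compounds shown, and "the series" means these compounds.

Of the compounds shown here, two have been measured in a functional assay on the whole organism with Mus musculus as the target; a lower number here means that less compound is needed, a higher number that more compound is needed for the effect. Compound 1 `C/C(C(N)=O)=C(/C)c1ccc(Cl)cc1` gives 20.9 mg/kg in this assay, and compound 2 `C/C(C(=O)NC1CC1)=C(/C)c1ccc(Cl)cc1` gives 11.4 mg/kg. For the measured compounds named here, the only step between them, a 1.8-fold lower number from compound 1 to compound 2 (0.26 log units; within the scatter), puts cyclopropyl in place of hydrogen on the amide-type nitrogen, and the two values sit within the scatter of each other, so compound 2 is not set apart from compound 1 on the numbers so far.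

Compound 3 `C/C(C(=O)NC1CC1)=C(\C)c1ccc(Cl)cc1` is the next compound. Its change from compound 2 is the two compounds have the same atoms and bonds and differ only in configuration as drawn: 1 of 1 stereo elements differ; a double bond is drawn E in compound 2 and Z in compound 3: the two compounds have the same atoms and bonds and differ only in configuration as drawn, the double bond being drawn E in compound 2 and Z in compound 3. Going by the values given here, no measured step bears on this change; the single measured step concerns the group on the nitrogen, not the geometry of the double bond, so it offers no guide to size or direction. A step of a 1.3-fold higher number from compound 2 to compound 3 (0.12 log units; within the scatter) is therefore expected, with a wide range around it. Compound 3 is estimated at 15 mg/kg, with a range from 5 mg/kg to 60 mg/kg.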

Compound 3, dose for half-maximal effect: 36.3 mg/kg
Estimate against measurement, compound 3: 2.4-fold (0.38 log units) below, and the stated range covers the measured number.
By their numbers in this assay, from the lowest: compounds 2, 1 and 3 (each within the scatter of the next, the first and the last beyond it).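

In this assay, the only earlier step, on the amide-type nitrogen, stayed within the scatter, so the series had shown no change that clearly moved the number. For the compounds shown here, the new step, a 3.2-fold higher number from compound 2 to compound 3 (0.50 log units; beyond the scatter), is the first to lie beyond the scatter, and it is a modest one, with no group entering or leaving. It can be assigned to the geometry of the double bond and to nothing else in the structure, because of one thing: the fact that compounds 2 and 3 differ only in the configuration as drawn. For this pair, then, the form drawn E in compound 2 needs less compound for the effect than the form drawn Z in compound 3, which shows that the arrangement about the double bond counts at this position even when every atom stays the same.

The compounds shown leave open whether the geometry gives a step of similar size and direction with anything other than cyclopropyl on the nitrogen, as the pair rests on that one amide. They also leave open how either geometry would fare with a longer chain on the nitrogen, or with a carboxylic acid in place of the amide.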